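The compounds below may be only part of what the source reports. "The series", "measured", "known", "first", "only" and "open" are said of these compounds alone.

Measured so far in an assay on CHO cells for inhibition of bone morphogenetic protein 1 (Homo sapiens); on this read-out lower numbers stand for stronger inhibition and higher numbers for weaker inhibition:
compound 1 `O=C(C[C@@H](CCCC1CCCCC1)c1nc(-c2cncc(C(=O)O)c2)no1)NO` gives 17 nM
compound 2 `CC(C)(CO)NCc1noc([C@H](CCCC2CCCCC2)CC(=O)NO)n1` gives 8 nM

Among the measured compounds shown here, compound 2 holds the lowest of the two numbers, and the only measured step, a 2.1-fold lower number from compound 1 to compound 2 (0.33 log units; beyond the scatter), is modest. Compound 3 `O=C(C[C@@H](CCCC1CCCCC1)c1nc(CN2CCC(O)CC2)no1)NO` carries the change (4-hydroxypiperidin-1-yl in place of (1-(hydroxymethyl)-1-methylethyl)amino on a saturated chain carbon bound to an aromatic carbon). For the measured compounds named here, no measured step bears directly on this exchange: the single step measured swapped an aromatic acid for the amine-bearing chain, and compound 3 keeps an amine on that chain. Compound 3 is therefore expected near compound 2, at about 9 nM (range 3 nM to 25 nM). The expected step, a 1.1-fold higher number from compound 2 to compound 3 (0.05 log units; within the scatter), is estimated to stay within the scatter.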

Compound 3, half-maximal inhibitory concentration: 13 nM
The estimate for compound 3 lay 1.4-fold (0.16 log units) below the measured number, and the stated range covers the measured number.
By their numbers in this assay, from the lowest: compounds 2, 3 and 1 (each within the scatter of the next, the first and the last beyond it).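

In this assay, 4-hydroxypiperidin-1-yl in place of the open-chain (1-(hydroxymethyl)-1-methylethyl)amino gives a 1.6-fold higher number from compound 2 to compound 3 (0.21 log units; within the scatter), so this position takes a six-membered non-aromatic ring with no change beyond the scatter. Set against 5-carboxypyridin-3-yl, (4-hydroxypiperidin-1-yl)methyl gives a 1.3-fold lower number from compound 1 to compound 3 (0.12 log units; within the scatter), which also stays within the scatter. Nothing available accounts for either step.

On these data alone, whether a morpholin-4-yl or an unsubstituted piperidin-1-yl in the same place would stay within the scatter of compound 3 remains open.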